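The source may hold more compounds than are shown below. What is called first, only, known or untested is meant among the compounds shown, and "the series" means these compounds.

For the measured compounds named here, in a functional assay on SK-BR-3 cells (Homo sapiens) for antiproliferative activity, read by MTT assay, with a stated time of 48 h (on this read-out lower numbers stand for stronger inhibition and higher numbers for weaker inhibition), compound 1 `COc1ccc(C(=O)Nc2ccc(N(C)S(C)(=O)=O)c(OCc3cc(Cl)ccc3Cl)c2)cc1` gives 490 nM and stands lowest of the three numbers so far. Compound 2 `COc1ccc(C(=O)Nc2ccc(N(C)S(C)(=O)=O)c(OCc3cc(Cl)ccc3Cl)c2)cc1OC` with 3730 nM and compound 3 `CN(c1ccc(NC(=O)c2ccc3ccccc3c2)cc1OCc1cc(Cl)ccc1Cl)S(C)(=O)=O` with 2210 nM both sit higher. Compound 4 `COc1ccc(C(=O)Nc2ccc(N(C)S(C)(=O)=O)c(OCc3cc(OC)ccc3OC)c2)cc1` is still unmeasured. It carries 2,5-dimethoxyphenyl in place of 2,5-dichlorophenyl on a saturated chain carbon bound to an oxygen on an aromatic ring. Going by the values given here, no measured step changes that group, so the evidence is indirect. The closest guide is methoxy in place of hydrogen on an aromatic carbon, which gave a 7.6-fold higher number from compound 1 to compound 2 (0.88 log units; beyond the scatter) and counts as a modest step. Naphthalen-2-yl in place of 4-methoxyphenyl also raised the number (a 4.5-fold higher number from compound 1 to compound 3 (0.65 log units; beyond the scatter)). A modest rise is therefore expected in this assay (a 2.9-fold higher number from compound 1 to compound 4 (0.46 log units; beyond the scatter)) with low confidence. For compound 4 the estimated value is 1400 nM (expected range 350 nM to 5000 nM).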

Compound 4, half-maximal inhibitory concentration: 2.56 nM
For compound 4 the middle estimate is 550-fold (2.74 log units) above the measured one; the whole stated range lies above it.
By their numbers in this assay, from the lowest: compound 4; then compound 1; then compounds 3 and 2 (each within the scatter of the next).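

In this assay, the 2,5-dichlorobenzyl group proves a far more sensitive place than the carbonyl side, with 2,5-dimethoxybenzyl giving a 190-fold lower number from compound 1 to compound 4 (2.28 log units; beyond the scatter). Methoxy does not act the same way everywhere, since methoxy in place of hydrogen on an aromatic carbon gave a 7.6-fold higher number from compound 1 to compound 2 (0.88 log units; beyond the scatter). No measurement shown here accounts for this large drop.

As far as these compounds go, it remains open whether one methoxy group alone would give the same drop, and whether its position on the ring matters. From the compounds shown here alone, the effect of an amine or a hydroxyl on this ring also remains unknown.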